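Amide-side aryl swap on the pyridyloxy ether series

The compounds below may be only part of what the source reports. "The series", "measured", "known", "first", "only" and "open" are said of these compounds alone.

Measured compounds:
compound 1, `CC(Oc1cccnc1Nc1cnn(C)c1)c1cccc(C(=O)NCc2ccc(F)cc2)c1`: 68500 nM
compound 2, `COc1ccc(CNC(=O)c2cccc(C(C)Oc3ccnc(Nc4cnn(C)c4)c3)c2)cc1OC`: 76600 nM

Both values come from a functional assay on HCC78 cells (Homo sapiens) for antiproliferative activity, read by MTT assay, with a stated time of 48 h; on this read-out lower numbers stand for stronger inhibition and higher numbers for weaker inhibition. Compound 1 gives 68500 nM and compound 2 gives 76600 nM; the two numbers sit within the scatter of each other, so neither can be placed above the other. Going by the values given here, compound 1 and compound 2 differ in more than one place, so no single step between them is counted. Among the compounds with values here, compound 2 is therefore the reference point for the next analogue, and it stands among only two weak numbers with no trend to lean on.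

Compound 3, `CC(Oc1ccnc(Nc2cnn(C)c2)c1)c1cccc(C(=O)NCc2cc(F)cc(F)c2)c1`, keeps the shared core of compound 2 and changes only the group on the amide side: 3,5-difluorophenyl in place of 3,4-dimethoxyphenyl on a saturated chain carbon bound to an amide-type nitrogen. Within the data shown here, no measured pair in this set isolates that change. Among the measured compounds shown here, with both known numbers already high in this assay and no counted step available, the expected step of a 1.2-fold lower number from compound 2 to compound 3 (0.07 log units; within the scatter) is none beyond the scatter, in either direction. For compound 3 the estimate in this assay is 65000 nM, with a range from 25000 nM to 160000 nM.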

Compound 3, half-maximal inhibitory concentration: 13200 nM
The estimate for compound 3 lay 4.9-fold (0.69 log units) above the measured number; the whole stated range lies above it.
By their numbers in this assay, from the lowest: compound 3; then compounds 1 and 2 (each within the scatter of the next).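

In this assay, going by these compounds alone, the amide side is the first place in this set where a single change moves the number beyond the scatter: 3,5-difluorophenyl in place of 3,4-dimethoxyphenyl, on a saturated chain carbon bound to an amide-type nitrogen, gives a 5.8-fold lower number from compound 2 to compound 3 (0.76 log units; beyond the scatter). Compound 1 and compound 2 differ in more than one place and could not show this, so the position now counts as one that responds, although on a single modest step and with compound 3 still at a high number, 13200 nM. Nothing in hand bears on why the step occurs.

Within the data shown here, the single step swaps both substituents at once, so the loss of the two methoxy groups and the arrival of the two fluorines cannot be separated, and a plain benzyl or a benzyl carrying one methoxy group or one fluorine would be needed to split them. Also open, as far as these compounds go, is whether the amide side keeps this response with something other than a substituted benzyl, such as a morpholine or a carboxylic acid on the chain.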